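The compounds below may be only part of what the source reports. "The series", "measured", "known", "first", "only" and "open" are said of these compounds alone.

Measured compounds in an assay for displacement of a labelled ligand from Sigma non-opioid intracellular receptor 1 (Cavia porcellus), read by scintillation counting, with a stated time of 180 min; on this read-out lower numbers stand for stronger inhibition and higher numbers for weaker inhibition:
Compound 1 `CC1(C)COC(CCCN2CCc3cc(OCc4ccccc4)ccc3C(O)C2)(c2ccc(C(C)(C)C)cc2)OC1` gives > 1000 nM, which is a limit of the assay and not a number.
Compound 2 `CN(Cc1ccccc1)C(=O)CN1CCc2cc(OCc3ccccc3)ccc2C(O)C1` gives > 1000 nM, likewise a limit rather than a number.
Compound 3 `OC1CN(Cc2ccc(N3CCCCC3)cc2)CCc2cc(OCc3ccccc3)ccc21` gives 604 nM.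

Compound 2 therefore stands at the limit of > 1000 nM in this assay, at which 2 of the 3 values shown sit; nothing beyond that is known of its inhibition constant, and compound 1 shares the same limit. Compound 3 is the only one of the three that returns a number in this assay.

Compound 4 `CN(Cc1ccccc1)C(=O)CN1CCc2cc(O)ccc2C(O)C1` has not yet been measured in this assay. It differs from compound 2 by hydrogen in place of benzyl on an oxygen on an aromatic ring, so that benzyloxy becomes hydroxy. For the measured compounds named here, no step between measured compounds covers this change, so its size cannot be read from the series. Given that compound 2 already sits at the limit of > 1000 nM in this assay, at which 2 of the 3 values shown sit, the step from compound 2 to compound 4 is expected to be small or to run toward weaker binding, as a step that the limit leaves unreadable from compound 2 to compound 4. Compound 4 is estimated at 3000 nM, within a range from 800 nM to 15000 nM, and most likely reported again only as a limit.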

Compound 4, inhibition constant: 172 nM
Beside the measured number, compound 4's estimate is 17-fold (1.24 log units) above it; the measured number lies below the stated range.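

The benzyl on this oxygen is not required for a measurable inhibition constant: all three earlier compounds carry benzyloxy, so none of them could show what this place contributes. In this assay, hydrogen in place of benzyl on an oxygen on an aromatic ring, so that benzyloxy becomes hydroxy, gives an at least 5.8-fold lower number from compound 2 to compound 4 (0.76 log units; beyond the scatter). The true size of this step remains unknown because compound 2 sits at a limit of the assay and not a number: the limit of > 1000 nM in this assay, at which 2 of the 4 values shown sit.

As far as these compounds go, whether the gain depends on the hydroxy itself or only on the loss of benzyl stays open, and methoxy at this oxygen would separate the two. Also open, from the compounds shown here alone, is whether the same change would lower the numbers of compound 1 and compound 3, which carry different groups on the ring nitrogen.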